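A few compounds are considered here, and "the series" means these few. Any claim that something is new, unique, unknown or untested is made for them only; others in the source may bear on it.

Measured compounds:
- compound 1 `COc1ccccc1-c1csc2cnc(Nc3ccc(NC(=O)[C@@H]4CCCNC4)cc3)nc12`: 410 nM
- compound 2 `COc1ccccc1-c1csc2cnc(Nc3ccc(C(=O)NCC4CCNCC4)c(F)c3)nc12`: 1530 nM
- compound 3 `COc1ccccc1-c1csc2cnc(Nc3ccc(C(=O)NC4CCNCC4)cc3C(F)(F)F)nc12`: 2750 nM

All three were tested in a functional assay on MDA-MB-231 cells (Homo sapiens) for inhibition, read by MTT assay, with a stated time of 72 h; on this read-out lower numbers stand for stronger inhibition and higher numbers for weaker inhibition. Compound 1 gives the lowest number of the three, and its distance from compound 2 and from compound 3 lies beyond the usual scatter of this assay, so among these three compound 1 is the strongest inhibitor. The three compounds differ in more than one place, so no single structural change can be tied to these gaps.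

Compound 4 `COc1ccccc1-c1csc2cnc(Nc3ccc(NC(=O)[C@H]4CCCNC4)cc3)nc12` has not yet been measured. It relates to compound 1 by the smallest change possible: the two compounds have the same atoms and bonds and differ only in configuration as drawn: 1 of 1 stereo elements differ; a stereocentre at a saturated ring carbon is drawn R in compound 1 and S in compound 4. For the measured compounds named here, nothing among the measured compounds shows how this assay responds to a change of configuration alone. A mirror-image partner can be a weaker inhibitor, or can behave much like the original, so the expected step from compound 1 to compound 4 is a 1.8-fold higher number from compound 1 to compound 4 (0.26 log units; within the scatter), a modest rise in the number that may well not exceed the scatter. The estimate for compound 4 in this assay is 750 nM, within a range from 200 nM to 3000 nM.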

Compound 4, half-maximal inhibitory concentration: 440 nM
For compound 4 the middle estimate is 1.7-fold (0.23 log units) above the measured one, within the range that was stated.
By their numbers in this assay, from the lowest: compounds 1 and 4 (each within the scatter of the next); then compounds 2 and 3 (each within the scatter of the next).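

In this assay, inverting the stereocentre at the saturated ring carbon gives a 1.1-fold higher number from compound 1 to compound 4 (0.03 log units; within the scatter), so the R and S forms cannot be told apart in this read-out. The earlier compounds offered no pair differing in one place, whereas this step can be read as the effect of configuration alone for one reason: the fact that compounds 1 and 4 differ only in the configuration as drawn. At this ring carbon, then, the drawn configuration is not what sets the number in these cells, at least with this amide and this shared core.

From the compounds shown here alone, what remains open is whether a methyl group on the nitrogen of the saturated ring, or a carboxylic acid in place of that ring, would shift the number. Compound 2 and compound 3 each differ from compound 1 in more than one place, so the structural change behind their higher numbers also remains unresolved.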